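A Pyridyl Amide in Place of a Methoxyphenyl Amide

The source may hold more compounds than are shown below. What is called first, only, known or untested is meant among the compounds shown, and "the series" means these compounds.

Compound 1, `COc1cccc(C(=O)Nc2cc(-c3ccccc3)nn2-c2ccccc2)c1`: 1290 nM
Compound 2, `N#Cc1cccc(C(=O)Nc2cc(-c3ccccc3)nn2-c2ccccc2Br)c1`: 230 nM

Both numbers come from an assay on HEK293 cells for displacement of a labelled ligand from metabotropic glutamate receptor 5 (Rattus norvegicus); a lower number here means a stronger inhibitor, a higher number a weaker inhibitor. For the measured compounds named here, compound 1 gives 1290 nM, the higher of the two numbers measured so far. Compound 2 gives 230 nM, a lower number, and the gap between the two lies beyond the scatter. Compound 2 differs from compound 1 in more than one place, so these two values show only that a different pairing of groups on the shared core can reach a lower number; no single change has been isolated between measured compounds.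

Compound 3, `O=C(Nc1cc(-c2ccccc2)nn1-c1ccccc1)c1ccncc1`, keeps the core of compound 1 and changes the amide side alone: pyridin-4-yl in place of 3-methoxyphenyl on a carbonyl carbon. A ring of carbon only carrying a methoxy group leaves, and a smaller ring with one nitrogen enters. Going by the values given here, no measured pair tests this change, so the expectation rests on compound 1 alone. The step of a 1.6-fold higher number from compound 1 to compound 3 (0.19 log units; within the scatter) is expected to be small, in the direction of a higher number, close to or just beyond the scatter. Compound 3 is estimated at 2000 nM, with a range from 600 nM to 6500 nM.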

Compound 3, inhibition constant: > 10000 nM
Compound 3: a limit, no number (the forecaster's own chance of this, stated with the estimate: 15%); middle value at least 5.0-fold (0.69 log units) away from the limit.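

For the compounds shown here, this is the first single change on the shared core whose effect can be read: on the amide side, pyridin-4-yl in place of 3-methoxyphenyl on a carbonyl carbon gives an at least 7.7-fold higher number from compound 1 to compound 3 (0.88 log units; beyond the scatter) in this assay. The entry for compound 3 is a limit of the assay and not a number: the limit of > 10000 nM in this assay, at which 1 of the 3 values shown sits. The group on this carbonyl carbon therefore matters in this assay, and one six-membered aromatic ring cannot simply stand in for another here, since the step lies beyond the scatter even as a minimum.

The change removes the methoxy group and puts a ring nitrogen in place of a ring carbon at once, so the compounds shown cannot say which of the two accounts for the step, or whether both contribute. From the compounds shown here alone, an unsubstituted phenyl ring or a pyridin-3-yl ring on the same carbonyl carbon would help to separate these two parts, and how far the step carries over to other groups at this place remains open.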